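The source may hold more compounds than are shown below. What is called first, only, known or untested is meant among the compounds shown, and "the series" means these compounds.

Of the compounds shown here, three from this series have been tested in a functional assay on MDA-MB-231 cells (Homo sapiens) for inhibition, read by sulforhodamine B assay, tested at 10 uM; a higher number here means more inhibition at the concentration tested (going by the name of the read-out), a lower number less inhibition. Compound 1 `CN(C)c1ccc(C2CC(c3ccc(-n4cncn4)cc3)=NN2S(C)(=O)=O)cc1` gives 7.8%. Compound 2 `Cc1ccc(S(=O)(=O)N2N=C(c3ccc(-n4cncn4)cc3)CC2c2ccc(N(C)C)cc2)cc1`, which carries 4-methylphenyl in place of methyl on a sulfonyl sulfur, gives 20.7%; the step of a number 12.9 percentage points higher from compound 1 to compound 2 (beyond the scatter) lies beyond the usual scatter of the measurement. Compound 3 `CN(C)c1ccc(C2CC(c3ccc(-n4ccnc4)cc3)=NN2S(C)(=O)=O)cc1` differs from compound 1 only in its core, through (1H-imidazol-1-yl in place of 1H-1,2,4-triazol-1-yl on an aromatic carbon). In this assay compound 3 gives 12%; here the step of a number 4.2 percentage points higher from compound 1 to compound 3 (within the scatter) stays within the scatter, so compound 1 and compound 3 cannot be told apart on this read-out.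

Compound 4 `Cc1ccc(S(=O)(=O)N2N=C(c3ccc(-n4ccnc4)cc3)CC2c2ccc(N(C)C)cc2)cc1` has not yet been measured. It stands to compound 3 as compound 2 stands to compound 1: the change is 4-methylphenyl in place of methyl on a sulfonyl sulfur, at the same place in both pairs, so it is the same change made on the other core. Going by the values given here, since the one measured example of this change, from compound 1 to compound 2, gave a number 12.9 percentage points higher from compound 1 to compound 2 (beyond the scatter), a step of about a number 13 percentage points higher from compound 3 to compound 4 (beyond the scatter) is expected here as well, resting on that single pair. Compound 4 is therefore estimated to give 25%, most likely between 12% and 38%.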

Compound 4, a percentage reported as inhibition, at one concentration (the size of the read-out at that concentration, not a potency): 50.8%
Compound 4: middle estimate off by 25.8 percentage points, on the low side; the measured number lies above the stated range.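

The sulfonyl change now gives a number 38.8 percentage points higher from compound 3 to compound 4 (beyond the scatter), so it points the same way on both cores, but its size does not carry over from one core to the other: the same change on two cores in this assay, a number 12.9 percentage points higher (beyond the scatter) from compound 1 to compound 2 and a number 38.8 percentage points higher (beyond the scatter) from compound 3 to compound 4, 25.9 percentage points apart, beyond the scatter of two such steps

Read the other way round, the change from 1H-1,2,4-triazol-1-yl to 1H-imidazol-1-yl gives a number 30.1 percentage points higher from compound 2 to compound 4 (beyond the scatter) when 4-methylphenyl sits on the sulfonyl sulfur, so the effect of this change also depends on its partner: the same change on two cores in this assay, a number 4.2 percentage points higher (within the scatter) from compound 1 to compound 3 and a number 30.1 percentage points higher (beyond the scatter) from compound 2 to compound 4, 25.9 percentage points apart, beyond the scatter of two such steps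

Both comparisons rest on the same four compounds and are one observation seen from two sides, so they show that the two changes do not simply add up in this set, but not why, nor whether this holds elsewhere in the series.

The compounds shown leave open whether another group on the sulfonyl sulfur, such as an ethyl chain or a 4-methoxyphenyl group, would also depend this strongly on the core. They also leave open whether the pattern would survive replacing the dimethylamino group with a methoxy group.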